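Ring Closure on the Side Chain: What to Expect for Compound 4

The compounds below may be only part of what the source reports. "The series", "measured", "known", "first", "only" and "open" are said of these compounds alone.

Measured compounds:
Compound 1 `CCCn1cnc2c(NC(=N)N)nc(N)nc21` gives 36500 nM
Compound 2 `CC(C)Cn1cnc2c(NC(=N)N)nc(N)nc21` gives 96600 nM
Compound 3 `CC(C)n1cnc2c(NC(=N)N)nc(NCCCO)nc21` gives 8800 nM

These three numbers come from a functional assay on MCF7 cells (Homo sapiens) for inhibition, read by fluorescence, with a stated time of 72 h; on this read-out lower numbers stand for stronger inhibition and higher numbers for weaker inhibition. Among them compound 3 stands lowest, so it is the strongest inhibitor in this small set, and its nearest neighbour is compound 1, with compound 2 furthest away. Among the compounds with values here, the only step that can be traced between compounds differing in one place is a 2.6-fold higher number from compound 1 to compound 2 (0.42 log units; beyond the scatter), which concerns the chain on the ring nitrogen and not the side the new compound changes.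

Compound 4 `CC(C)n1cnc2c(NC(=N)N)nc(N3CCC[C@H]3CO)nc21` differs from compound 3 by 2-(hydroxymethyl)pyrrolidin-1-yl in place of (3-hydroxypropyl)amino on an aromatic carbon. The open chain becomes a ring, and one hydrogen-bond donor is lost. Within the data shown here, no measured pair shows what this change does; the step from compound 1 to compound 2 tells only that altering a small chain elsewhere on the core moved the number modestly. Among the measured compounds shown here, with no guiding step, the expectation is for a change that may be small or may fall beyond the scatter, with the direction open, and the estimated step is a 1.7-fold higher number from compound 3 to compound 4 (0.23 log units; within the scatter). Compound 4 is therefore expected to give about 15000 nM in this assay, within a range from 4000 nM to 60000 nM.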

Compound 4, half-maximal inhibitory concentration: 6200 nM
Estimate against measurement, compound 4: 2.4-fold (0.38 log units) above, within the range that was stated.
By their numbers in this assay, from the lowest: compounds 4 and 3 (each within the scatter of the next); then compound 1; then compound 2.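

Replacing (3-hydroxypropyl)amino with 2-(hydroxymethyl)pyrrolidin-1-yl on this aromatic carbon, the one between two ring nitrogen atoms, gives in this assay a 1.4-fold lower number from compound 3 to compound 4 (0.15 log units; within the scatter), so this read-out cannot tell the two compounds apart. This position therefore accepts a group with more heavy atoms, a five-membered non-aromatic ring, a defined stereocentre and one hydrogen-bond donor fewer, with no shift beyond the usual scatter of repeated measurements. No supporting data accompany this result, so nothing here explains why the number held.

The compounds shown leave open whether the stereocentre matters, since the opposite mirror-image form of the 2-(hydroxymethyl)pyrrolidin-1-yl group does not appear among them, and whether the hydroxyl matters, since neither a plain pyrrolidine ring nor a methyl group in place of the hydroxymethyl appears either. They also leave open how far this position would stay as accepting with a group of another kind, such as a carboxylic acid on the ring, a morpholine ring or a longer hydroxyalkyl chain.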